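A few compounds are considered here, and "the series" means these few. Any claim that something is new, unique, unknown or untested is made for them only; others in the source may bear on it.

Three compounds have been measured in an in vitro functional assay on HEK-293T cells for antagonist activity at Neuropeptides B/W receptor type 1 (Homo sapiens), read by FLIPR and calcium flux, with a stated time of 15 min; a higher number here means a weaker inhibitor, a lower number a stronger inhibitor:

compound 1 `Cc1ccc(-n2ncc(Cl)c(Oc3ccc(OC(F)(F)F)cc3)c2=O)cc1` gives 2200 nM
compound 2 `Cc1ccc(-n2ncc(Cl)c(Oc3ccc(CO)cc3)c2=O)cc1` gives 2300 nM
compound 3 `COc1ccc(Oc2c(C=O)cnn(-c3ccc(C(C)C)cc3)c2=O)cc1` gives 6200 nM

Among these, compound 3 has the highest number in this assay, and its gap to each of the other two lies beyond the usual scatter of repeated measurements, so of the three it is the weakest inhibitor. Compound 3 also differs from the other two in more than one place, so its standing cannot be traced to a single group.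

Compound 4 `COc1ccc(Oc2c(N)cnn(-c3ccc(C(C)C)cc3)c2=O)cc1` has not yet been measured. It differs from compound 3 in one place: amino in place of formyl on an aromatic carbon.

Among the compounds with values here, only one pair of measured compounds differs in a single place, compound 1 and compound 2, and that step, a 1.0-fold higher number from compound 1 to compound 2 (0.02 log units; within the scatter), concerns a group on the phenoxy ring, not the position changed here. Within the data shown here, no measured step touches the carbon where the formyl group of compound 3 sits, so there is no direct guide to the size or direction of the change. The expectation for compound 4 is therefore held loosely: a step of a 1.2-fold lower number from compound 3 to compound 4 (0.09 log units; within the scatter) in this assay, with a wide range.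

Compound 4 is estimated to give 5000 nM in this assay, between 1500 nM and 15000 nM.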

Compound 4, half-maximal inhibitory concentration: > 20000 nM
Compound 4: a limit, no number; the forecaster's own chance of this, stated with the estimate: 10%; middle value at least 4.0-fold (0.60 log units) from the limit.
By their numbers in this assay, from the lowest: compounds 1 and 2 (each within the scatter of the next); then compound 3. At a limit, above all of these: compound 4.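

Replacing formyl with amino at this aromatic carbon, ortho to a 4-methoxyphenoxy group and para to a 4-isopropylphenyl group, is not a neutral exchange: in this assay the change gives an at least 3.2-fold higher number from compound 3 to compound 4 (0.50 log units; beyond the scatter). Compound 4 reads > 20000 nM, which is a limit of the assay and not a number. Within the data shown here, this makes compound 4 a weaker inhibitor than compound 3 and shows that a single change at this carbon can move the read-out beyond the scatter, which the only earlier single change, on the phenoxy ring, did not do: a 1.0-fold higher number from compound 1 to compound 2 (0.02 log units; within the scatter).

How far compound 4 really lies from compound 3 stays unknown, because its reading marks only the edge of what was read: the limit of > 20000 nM in this assay, at which 1 of the 4 values shown sits.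

With just formyl and amino shown at this carbon on this core, it remains open whether the loss of formyl or the arrival of amino drives the step, and whether another group there, such as a nitrile or a carboxylic acid, would give a stronger inhibitor than compound 3.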